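The source may hold more compounds than are shown below. What is called first, only, known or untested is meant among the compounds shown, and "the series" means these compounds.

Among the measured compounds shown here, compound 1 `O=C(Nc1ccc(-n2ncc3c(Cl)cccc32)cc1)Nc1ccc(Cl)c(C(F)(F)F)c1` is one of two compounds with a number so far in a functional assay on OS-RC-2 cells (Homo sapiens) for cytotoxicity, read by MTT assay, with a stated time of 72 h; a lower number here means a stronger inhibitor, a higher number a weaker inhibitor. In this assay compound 1 gives 3100 nM, the lowest of the two numbers. Compound 2 `O=C(Nc1ccc(-n2ncc3c(Cl)cccc32)cc1)Nc1ccc(C(F)(F)F)cc1` sits closest to it; in this assay compound 2 gives 4600 nM, and the gap between these two values lies within the scatter, so the pair shows no real difference.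

Compound 3 `O=C(Nc1ccc(-n2ncc3ccncc32)cc1)Nc1ccc(Cl)c(C(F)(F)F)c1` has not yet been measured. Relative to compound 1 it carries a group of 9 heavy atoms (6 carbon, 3 nitrogen; one five-membered aromatic ring with 2 hetero atoms, one six-membered aromatic ring with 1 hetero atom) in place of a group of 10 heavy atoms (7 carbon, 2 nitrogen, 1 chlorine; one five-membered aromatic ring with 2 hetero atoms, one six-membered aromatic ring of carbon only), on an aromatic carbon, the ring system that sits on an aromatic carbon of a six-membered aromatic ring of carbon only, para to a large group. For the measured compounds named here, no measured pair here shows the effect of such a change, so the expectation rests on the value of compound 1 alone. For compound 3 the expected step from compound 1 is a 1.6-fold higher number from compound 1 to compound 3 (0.21 log units; within the scatter), a modest move toward a weaker inhibitor that may not exceed the scatter. Compound 3 is therefore estimated at 5000 nM, within a range of 1500 nM to 20000 nM.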

Compound 3, half-maximal inhibitory concentration: > 32000 nM
Compound 3: no number, only a limit; the forecaster's own chance of this, stated with the estimate: 10%; middle value at least 6.4-fold (0.80 log units) from the limit.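

Replacing the 4-chloro-1H-indazol-1-yl group with the ring system of compound 3, on this aromatic carbon para to a large group, gives an at least 10-fold higher number from compound 1 to compound 3 (1.01 log units; beyond the scatter) in this assay. Compound 1 and compound 2 carry the same group at this place, so they could not show that a change here can matter this much. Compound 3 has a limit and not a number, so the step gives only a minimum size: the limit of > 32000 nM in this assay, at which 1 of the 3 values shown sits.

This single change removes the chlorine and adds a ring nitrogen together, so the compounds shown cannot tell which of the two accounts for the step. A plain 1H-indazol-1-yl group, or a methyl or methoxy group in place of the chlorine, would be needed to separate the two.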